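Cytotoxicity notes: from compound 1 toward compound 4

The source may hold more compounds than are shown below. What is called first, only, known or untested is meant among the compounds shown, and "the series" means these compounds.

Three members of the series have been read in an ADME assay on BHK-21 cells (Mesocricetus auratus) for cytotoxicity, read by MTT assay, with a stated time of 72 h; on this read-out higher numbers stand for lower toxicity in this test and lower numbers for higher toxicity in this test. Compound 1 `Cc1ccccc1C1CC(c2ccc(OCc3ccccc3)cc2)=NN1c1ccc(S(N)(=O)=O)cc1` gives 20000 nM, the highest of the three numbers. Compound 3 `Cc1ccccc1C1CC(c2ccccc2)=NN1c1ccc(S(N)(=O)=O)cc1` gives 14000 nM, and the step of a 1.4-fold lower number from compound 1 to compound 3 (0.15 log units; within the scatter) shows that dropping the benzyloxy group leaves the read-out within the scatter. Compound 2 `Cc1ccc(C2CC(c3ccccc3)=NN2c2ccc(S(N)(=O)=O)cc2)cc1` gives 7000 nM; its gap to compound 1 is the widest in the set and lies beyond the scatter, though compound 2 differs from compound 1 in two places, so no single change can be credited.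

Compound 4 `NS(=O)(=O)c1ccc(N2N=C(c3ccc(OCc4ccccc4)cc3)CC2c2cccc(F)c2)cc1` is the next member due for this assay. It differs from compound 1 in one place: 3-fluorophenyl in place of 2-methylphenyl on a saturated ring carbon. Within the data shown here, the nearest precedent is the exchange of aryl groups at the same saturated ring carbon, a 2.0-fold higher number from compound 2 to compound 3 (0.30 log units; within the scatter), which stays within the scatter. The benzyloxy group is kept in compound 4, so the step from compound 1 to compound 3 is only a reminder that the sulfamoylphenyl-bearing core tolerates small edits without a large shift in this assay.

On that basis no step beyond the scatter is expected for compound 4, and the estimated change is a 1.2-fold lower number from compound 1 to compound 4 (0.07 log units; within the scatter). Compound 4 is therefore estimated at 17000 nM, with a range from 7000 nM to 40000 nM.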

Compound 4, half-maximal cytotoxic concentration: 9000 nM
Estimate against measurement, compound 4: 1.9-fold (0.28 log units) above; the measured number falls inside the stated range.
By their numbers in this assay, from the lowest: compounds 2, 4, 3 and 1 (each within the scatter of the next, the first and the last beyond it).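

In this assay, among these compounds, 3-fluorophenyl in place of 2-methylphenyl on the saturated ring carbon gives a 2.2-fold lower number from compound 1 to compound 4 (0.35 log units; beyond the scatter), a modest step but the first single-place step to lie beyond the scatter. This position, next to the ring atom that bears a 4-sulfamoylphenyl group, can therefore shift the read-out toward higher toxicity in this test when one aryl group replaces another, whereas the earlier exchange at the same carbon, a 2.0-fold higher number from compound 2 to compound 3 (0.30 log units; within the scatter), stayed within the scatter and involved a different pair of aryl groups on a core without the benzyloxy group. No measured evidence accounts for this shift.

The compounds shown leave open whether the step follows the arrival of the fluorine, the loss of the methyl or the change of ring position, which a 3-methylphenyl or 2-fluorophenyl group at this carbon would help to separate. Also open, from the compounds shown here alone, are whether the step persists with hydrogen in place of benzyloxy and how a carboxylic acid or an amine on this aryl group would read.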